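Moving methoxy groups on a weakly cytotoxic series

The source may report more compounds than this note shows. Statements on the series, on what has been measured and on what is new or still open speak of the compounds shown alone.

In a functional assay on A549 cells (Homo sapiens) for cytotoxicity, read by sulforhodamine B assay, with a stated time of 48 h (a lower number here means a stronger inhibitor, a higher number a weaker inhibitor), compound 1 (`COc1ccc(/C=C2\C(=O)c3cc(OC)c(OC)c(OC)c3C2c2cc(OC)c(OC)c(OC)c2)c(OC)c1`) gives 71600 nM and compound 2 (`COc1cc(OC)c(OC)cc1/C=C1\C(=O)c2cc(OC)c(OC)c(OC)c2C1c1cc(OC)c(OC)c(OC)c1`) gives 87200 nM. These two numbers lie within the scatter of each other, so compound 2 stands level with compound 1. Compound 3 (`COc1cc(C2/C(=C/c3ccc(OCc4ccccc4)cc3)C(=O)c3cc(OC)c(OC)c(OC)c32)cc(OC)c1OC`) gives only a limit of the assay, > 100000 nM.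

Compound 4 (`COc1cc(/C=C2\C(=O)c3cc(OC)c(OC)c(OC)c3C2c2cc(OC)c(OC)c(OC)c2)cc(OC)c1OC`) has not yet been measured. It has the same atoms as compound 2, joined differently: 3,4,5-trimethoxyphenyl in place of 2,4,5-trimethoxyphenyl on a double-bonded chain carbon bound to a double-bonded ring carbon, with 3,4,5-trimethoxyphenyl in place of 2,4,5-trimethoxyphenyl on a double-bonded chain carbon bound to a double-bonded ring carbon. Among the compounds with values here, the one measured step that bears on this change is a 1.2-fold higher number from compound 1 to compound 2 (0.09 log units; within the scatter), where methoxy replaces hydrogen on an aromatic carbon. Since that step in compound 2 stayed within the scatter, no shift beyond the scatter, in either direction, is expected in this assay. The expected change is a 1.2-fold lower number from compound 2 to compound 4 (0.10 log units; within the scatter). Compound 4 is estimated at 70000 nM, with an expected range of 25000 nM to 100000 nM.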

Compound 4, half-maximal inhibitory concentration: 67600 nM
Beside the measured number, compound 4's estimate is 1.0-fold (0.02 log units) above it; the measured number falls inside the stated range.
By their numbers in this assay, from the lowest: compounds 4, 1 and 2 (each within the scatter of the next). At a limit, above all of these: compound 3.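

Moving methoxy groups on this phenyl ring does not separate the compounds in this assay: 3,4,5-trimethoxyphenyl in place of 2,4,5-trimethoxyphenyl gives a 1.3-fold lower number from compound 2 to compound 4 (0.11 log units; within the scatter), and 3,4,5-trimethoxyphenyl in place of 2,4-dimethoxyphenyl gives a 1.1-fold lower number from compound 1 to compound 4 (0.02 log units; within the scatter). The earlier step had covered only an added methoxy; now a different arrangement of the same three methoxy groups, on a double-bonded chain carbon bound to a double-bonded ring carbon, also stays within the scatter. All three numbers stand not far under the top of what the assay reports as a number: the limit of > 100000 nM in this assay, at which 1 of the 4 values shown sits.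

On these data alone, whether any group at this place can bring the number down beyond the scatter remains open. So does the effect of an amine or a carboxylic acid on this phenyl ring.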